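A Second Bromo Substituent in a Series of Weak Inhibitors

The source may hold more compounds than are shown below. What is called first, only, known or untested is meant among the compounds shown, and "the series" means these compounds.

Measured so far:
compound 1 `COc1cc(/C=N/Nc2nc(-c3cccc(Br)c3)cs2)cc(Br)c1OC`: 66200 nM
compound 2 `COc1cc(/C=N/Nc2nc(-c3cc(C(F)(F)F)cc(C(F)(F)F)c3)cs2)cc(Br)c1OC`: > 100000 nM
compound 3 `COc1cc(/C=N/Nc2nc(-c3cccc(Br)c3)cs2)c(Br)c(Br)c1OC`: > 100000 nM

All three were tested in a functional assay on HepG2 cells (Homo sapiens) for inhibition, read by MTT assay, with a stated time of 48 h; a lower number here means a stronger inhibitor, a higher number a weaker inhibitor. Compound 1 gives a number, 66200 nM. For compound 2 the assay reports only a limit, > 100000 nM. For compound 3 likewise only a limit is reported, > 100000 nM. The change is bromo in place of hydrogen on an aromatic carbon, and the outcome is an at least 1.5-fold higher number from compound 1 to compound 3 (0.17 log units; that floor lies within the scatter), a floor rather than a full step because of the limit of > 100000 nM in this assay, at which 2 of the 3 values shown sit. The difference between the core of compound 1 and the core of compound 2 is not broken down here.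

Compound 4 `COc1cc(/C=N/Nc2nc(-c3cc(C(F)(F)F)cc(C(F)(F)F)c3)cs2)c(Br)c(Br)c1OC` is not yet measured. It differs from compound 2 by bromo in place of hydrogen on an aromatic carbon, the same change that was made from compound 1 to compound 3. Compound 2 already stands at a limit, > 100000 nM. Compound 4 is therefore expected to remain at or beyond that limit, estimated at 150000 nM, with a likely range from 90000 nM to 400000 nM. This expected step that the limit leaves unreadable from compound 2 to compound 4 in this assay rests on the limit of compound 2 and on an at least 1.5-fold higher number from compound 1 to compound 3 (0.17 log units; that floor lies within the scatter), which did not make the number smaller.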

Compound 4, half-maximal inhibitory concentration: > 100000 nM
Compound 4: no number, only a limit; the forecaster's own chance of this, stated with the estimate: 90%; the middle value does not contradict the limit.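

Among these compounds, compound 4 gives only a limit in this assay, > 100000 nM, and compound 2 also gives only a limit, so no step between them can be read: the limit of > 100000 nM in this assay, at which 3 of the 4 values shown sit. The compounds shown leave open how much the added bromo truly changes the number in either pair.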